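Working notes: amide nitrogen change toward compound 3

The compounds below may be only part of what the source reports. "The series", "measured", "known", "first", "only" and "open" are said of these compounds alone.

Measured so far:
compound 1 `CCOc1ccc2cc(C(=O)NCCO)c(=O)oc2c1` — > 100000 nM
compound 2 `CCCOc1ccc2cc(C(=O)NCCO)c(=O)oc2c1` — 22600 nM

In a functional assay on HeLa cells (Homo sapiens) for cytotoxicity, read by MTT assay, with a stated time of 72 h (on this read-out lower numbers stand for stronger inhibition and higher numbers for weaker inhibition), compound 1 gives > 100000 nM, which is a limit of the assay and not a number. In this assay, for the measured compounds named here, compound 2 gives 22600 nM, the only number. Going by the values given here, the single measured step, an at least 4.4-fold lower number from compound 1 to compound 2 (0.64 log units; beyond the scatter), comes from methyl in place of hydrogen on a saturated chain carbon, two bonds along the chain from an oxygen on an aromatic ring; it is at least modest.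

Compound 3 `CCCOc1ccc2cc(C(=O)NN)c(=O)oc2c1` differs from compound 2 by amino in place of 2-hydroxyethyl on an amide-type nitrogen. Among the compounds with values here, no measured step touches an amide-type nitrogen, so none bears on this change, and no step beyond the scatter is expected in this assay, in either direction. Compound 3 is therefore estimated at 25000 nM (range 8000 nM to 80000 nM), a step of a 1.1-fold higher number from compound 2 to compound 3 (0.04 log units; within the scatter) that is expected to stay within the scatter.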

Compound 3, half-maximal inhibitory concentration: > 100000 nM
Compound 3 was reported as a limit; the forecaster's own chance of this, stated with the estimate: 25%; at least 4.0-fold (0.60 log units) between middle value and limit.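

The amide-type nitrogen, untouched by the earlier step, proves sensitive to substitution in this assay: amino in place of 2-hydroxyethyl gives an at least 4.4-fold higher number from compound 2 to compound 3 (0.64 log units; beyond the scatter). The value of compound 3 is a limit of the assay and not a number, so the full size of this change stays unknown: the limit of > 100000 nM in this assay, at which 2 of the 3 values shown sit.

For the compounds shown here, compound 2 therefore remains the only compound with a number. Open, on these data alone, is whether the hydroxyl or the two-carbon chain of 2-hydroxyethyl matters, which a 2-methoxyethyl or an ethyl group on that nitrogen would address. Also open, as far as these compounds go, is how a longer chain on the aromatic-ring oxygen would read.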